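Bromo to benzyloxy exchange in a bis-enone series

The compounds below may be only part of what the source reports. "The series", "measured", "known", "first", "only" and "open" are said of these compounds alone.

Measured compounds:
compound 1 `Cc1cc(O)c(C(=O)/C=C/c2ccccc2)c(-c2ccc(Br)cc2)c1C(=O)/C=C/c1ccccc1`, 8000 nM
compound 2 `Cc1cc(O)c(C(=O)/C=C/c2ccc(F)cc2)c(-c2ccc(OCc3ccccc3)cc2)c1C(=O)/C=C/c1ccc(F)cc1`, 15000 nM
compound 3 `Cc1cc(O)c(C(=O)/C=C/c2ccc(F)cc2)c(-c2ccc(Br)cc2)c1C(=O)/C=C/c1ccc(F)cc1`, 22300 nM

All three were run in a functional assay on MDA-MB-231 cells (Homo sapiens) for cytotoxicity, read by MTT assay, with a stated time of 24 h; a lower number here means a stronger inhibitor, a higher number a weaker inhibitor. Compound 1 gives the lowest number of the three; its gap to compound 2 lies within the usual scatter, while its gap to compound 3 lies beyond it. How the core of compound 1 differs from the core of compound 3 is not broken down here.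

One pair of measured compounds differs in a single place: compound 3 and compound 2, where the change is benzyloxy in place of bromo on an aromatic carbon. This change gives a 1.5-fold lower number from compound 3 to compound 2 (0.17 log units; within the scatter), so on its own it leaves the read-out essentially where it was.

Compound 4 `Cc1cc(O)c(C(=O)/C=C/c2ccccc2)c(-c2ccc(OCc3ccccc3)cc2)c1C(=O)/C=C/c1ccccc1` is not yet measured. It is related to compound 1 by benzyloxy in place of bromo on an aromatic carbon, the same change as that between compound 3 and compound 2, at the same place. If the change behaves as it did there, the expected step is a 1.3-fold lower number from compound 1 to compound 4 (0.12 log units; within the scatter) in this assay, resting on a 1.5-fold lower number from compound 3 to compound 2 (0.17 log units; within the scatter); the only caution is that the two cores differ, and there is a single precedent.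

Compound 4 is therefore estimated at 6000 nM in this assay, with an expected range from 3000 nM to 14000 nM.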

Compound 4, half-maximal inhibitory concentration: "not active" (no number reported)
No number was reported for compound 4, and the estimate cannot be compared.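

In this assay, within the data shown here, compound 4 is reported as "not active" with no number, so no step from compound 1 to compound 4 can be read. Nothing available bears on the cause of this result. The compounds shown leave open whether benzyloxy in place of bromo acts differently on the core of compound 1 than on the core of compound 3.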